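Aryl variation in the imidazoline ether series

The source may report more compounds than this note shows. Statements on the series, on what has been measured and on what is new or still open speak of the compounds shown alone.

Measured so far:
compound 1, `CC(Oc1ccccc1-c1ccc([N+](=O)[O-])cc1)C1=NCCN1`: 302 nM
compound 2, `Cc1ccc(-c2ccccc2OC(C)C2=NCCN2)cc1`: 251 nM
compound 3, `CC(Oc1ccccc1-c1ccncc1)C1=NCCN1`: 1450 nM

In an assay on CHO cells for displacement of a labelled ligand from Alpha-2C adrenergic receptor (Homo sapiens) (on this read-out lower numbers stand for stronger inhibition and higher numbers for weaker inhibition), compound 2 sits at the low end of the three numbers. Compound 1 is within the scatter of it (a 1.2-fold lower number from compound 1 to compound 2 (0.08 log units; within the scatter)), while compound 3 lies clearly beyond it (a 5.8-fold higher number from compound 2 to compound 3 (0.76 log units; beyond the scatter)).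

Compound 4, `CC(Oc1ccccc1-c1ccccc1O)C1=NCCN1`, is not yet measured in this assay. Against compound 2 the change is: 2-hydroxyphenyl in place of 4-methylphenyl on an aromatic carbon.

Within the data shown here, two measured steps bear on this. The exchange of nitro for methyl on the distal ring was within the scatter, so a change of substituent alone on that ring need not move the number. The exchange of 4-methylphenyl for pyridin-4-yl, which brings in a hydrogen-bond acceptor, gave a modest rise. The 2-hydroxyphenyl of compound 4 brings in one hydrogen-bond donor and one hydrogen-bond acceptor, so a step toward a higher number in this assay is expected, smaller than that seen with compound 3, and a result within the scatter of compound 2 cannot be ruled out. The expected step is a 2.4-fold higher number from compound 2 to compound 4 (0.38 log units; beyond the scatter). For compound 4 the estimate is 600 nM, with a range of 250 nM to 1500 nM.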

Compound 4, inhibition constant: 1620 nM
Beside the measured number, compound 4's estimate is 2.7-fold (0.43 log units) below it, outside the stated range (above it).
By their numbers in this assay, from the lowest: compounds 2 and 1 (each within the scatter of the next); then compounds 3 and 4 (each within the scatter of the next).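

In this assay, 2-hydroxyphenyl in place of 4-methylphenyl on this aromatic carbon gives a 6.5-fold higher number from compound 2 to compound 4 (0.81 log units; beyond the scatter), so a distal ring of carbon only can still carry a step of this size, and a ring nitrogen as in compound 3 is not required for it. The exchange of 2-hydroxyphenyl for pyridin-4-yl gives a 1.1-fold higher number from compound 3 to compound 4 (0.05 log units; within the scatter), placing the two groups level at this position, while the nitro group of compound 1 stays within the scatter of compound 2 and goes against any reading that a heteroatom on the distal ring is enough to raise the number. Nothing measured here speaks to the origin of this rise.

In compound 4 both the substituent and its place on the distal ring differ from compound 2, so the compounds shown do not tell whether the hydroxyl group or its place goes with the higher number, a question that 2-methylphenyl and 4-hydroxyphenyl at this carbon would separate. Also open, on these data alone, is how 2-methoxyphenyl, which caps the hydroxyl oxygen with a methyl group, or an aminophenyl or carboxyphenyl group would read in this assay.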